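This account rests on a few compounds, and the source may have more. Where it says the series, first, only, none or still open, it means among the compounds named here.

Compound 1, `Cn1c(-c2ccc(-c3cncnc3)cc2)nnc1C1(c2ccc(Cl)cc2)CCC1`, gives > 4000 nM in an assay on isolated protein for inhibition of 11-beta-hydroxysteroid dehydrogenase type 2 (Homo sapiens) (a higher number here means a weaker inhibitor, a lower number a stronger inhibitor), a limit of the assay rather than a number.
Compound 2, `CC(=O)Nc1ccc(-c2nnc(C3(c4ccc(Cl)cc4)CCC3)n2C)c(Cl)c1`, gives > 4000 nM in this assay, again a limit.
Compound 3, `Cn1c(-c2ccc(C(N)=O)cc2C(N)=O)nnc1C1(c2ccc(Cl)cc2)CCC1`, gives > 4000 nM in this assay, also a limit.

Compound 2 therefore stands at the limit of this assay, and none of the three measured compounds returns a number: the limit of > 4000 nM in this assay, at which 3 of the 3 values shown sit. The step to the unmeasured compound 4, `Cn1c(-c2ccc(C(=O)O)cc2Cl)nnc1C1(c2ccc(Cl)cc2)CCC1`, replaces one group on the aromatic ring attached to the shared core: carboxy in place of acetamido on an aromatic carbon, meta to a chloro group and para to a large group. Among the compounds with values here, no step between two measured compounds has been recorded, so the size of this change cannot be read off from a neighbour. Within the data shown here, since every value so far sits at the limit, no direction is suggested by the data; the expected step that the limit leaves unreadable from compound 2 to compound 4 is one of no change beyond the scatter. Compound 4 is therefore estimated at 8000 nM, with a range from 3000 nM to 30000 nM, and most likely the assay will again report only a limit.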

Compound 4, half-maximal inhibitory concentration: > 4000 nM
Compound 4 ended at the assay's limit; the forecaster's own chance of this, stated with the estimate: 80%; the middle value is on the limit's open side.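

No new step can be read between compound 2 and compound 4, because both values are limits and not numbers: the limit of > 4000 nM in this assay, at which 4 of the 4 values shown sit.
The compounds shown leave open, in this assay and for all four compounds, how weak each inhibitor really is and whether carboxy in place of acetamido makes any difference.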